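Dimethylphenyl amide after the cyanophenyl analogue

A few compounds are considered here, and "the series" means these few. Any claim that something is new, unique, unknown or untested is made for them only; others in the source may bear on it.

Compound 1 `Cc1cc(C(=O)NCN2CCC(c3cccc[n+]3[O-])CC2)ccc1F`: 50 nM
Compound 2 `C=Cc1cccc(C(=O)NCN2CCC(c3cccc[n+]3[O-])CC2)c1`: 68 nM
Compound 3 `N#Cc1cccc(C(=O)NCN2CCC(c3cccc[n+]3[O-])CC2)c1`: 840 nM

In a functional assay on HEK293 cells for agonist activity at D(4) dopamine receptor (Homo sapiens), read by FLIPR (on this read-out higher numbers stand for an effect only at larger amounts of compound and lower numbers for an effect already at smaller amounts), compound 3 stands highest of the three numbers, well apart from both other compounds. Compound 4 `Cc1ccc(C(=O)NCN2CCC(c3cccc[n+]3[O-])CC2)cc1C` is its unmeasured partner; the change is 3,4-dimethylphenyl in place of 3-cyanophenyl on a carbonyl carbon. For the measured compounds named here, two measured steps bear on it, both ending at compound 3: a 17-fold higher number from compound 1 to compound 3 (1.23 log units; beyond the scatter) and a 12-fold higher number from compound 2 to compound 3 (1.09 log units; beyond the scatter). Each was large and each ran toward higher numbers as the cyanophenyl entered; the step to compound 4 removes that group again and brings in a phenyl carrying only methyl groups, closest in kind to compound 1. The number for compound 4 is therefore expected to fall sharply, by about a 14-fold lower number from compound 3 to compound 4 (1.15 log units; beyond the scatter). The estimate for compound 4 is 60 nM, with a range from 25 nM to 150 nM.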

Compound 4, half-maximal effective concentration: 38 nM
For compound 4 the middle estimate is 1.6-fold (0.20 log units) above the measured one; the range from low to high includes it.
By their numbers in this assay, from the lowest: compounds 4, 1 and 2 (each within the scatter of the next); then compound 3.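

At this place on a carbonyl carbon, this assay shows that 3,4-dimethylphenyl recovers what 3-cyanophenyl lost, with a 22-fold lower number from compound 3 to compound 4 (1.34 log units; beyond the scatter) as the step. Both a 1.8-fold lower number from compound 2 to compound 4 (0.25 log units; within the scatter) and a 1.3-fold lower number from compound 1 to compound 4 (0.12 log units; within the scatter) lie within the scatter, so among these four only the nitrile-bearing compound 3 stands apart. Nothing measured here gives a reason for this difference. Whether that separation belongs to the nitrile alone stays open, since the compounds shown do not tell where a phenyl carrying an amine, a carboxylic acid or a methoxy group would fall.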